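Trifluoromethyl for methoxy on a diaryl urea core

A few compounds are considered here, and "the series" means these few. Any claim that something is new, unique, unknown or untested is made for them only; others in the source may bear on it.

Measured compounds:
Compound 1, `CCNc1cc(-c2ccc(NC(=O)Nc3ccc(OC)cc3)cc2C(F)(F)F)ccn1`, gives 17600 nM.
Compound 2, `CCNc1cc(-c2ccc(NC(=O)Nc3ccc(OC)cc3)cc2OC)ccn1`, is reported only as a limit of the assay, > 30000 nM.
Compound 3, `CCNc1cc(-c2ccc(NC(=O)Nc3ccc(OC)cc3)cc2F)ccn1`, gives 19600 nM.

All three were tested in a functional assay on BT-483 cells (Homo sapiens) for cytotoxicity, read by MTT assay, with a stated time of 24 h; a lower number here means a stronger inhibitor, a higher number a weaker inhibitor. Compound 2 sits at the limit of > 30000 nM in this assay, at which 1 of the 3 values shown sits, so its value is a limit and not a number. The change from compound 2 to compound 1 is trifluoromethyl in place of methoxy on an aromatic carbon, and it gave an at least 1.7-fold lower number from compound 2 to compound 1 (0.23 log units; that floor lies within the scatter). The cores of compound 2 and compound 3 differ by fluoro in place of methoxy on an aromatic carbon, with an at least 1.5-fold lower number from compound 2 to compound 3 (0.18 log units; that floor lies within the scatter). Between compound 1 and compound 3 the step is a 1.1-fold higher number from compound 1 to compound 3 (0.05 log units; within the scatter).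

Compound 4, `CCNc1cc(-c2ccc(NC(=O)Nc3ccc(C(F)(F)F)cc3)cc2F)ccn1`, has not yet been measured. It differs from compound 3 by trifluoromethyl in place of methoxy on an aromatic carbon. For the measured compounds named here, this is the same kind of change as the one from compound 2 to compound 1, but the place is not the same: there the group stood ortho to a 2-(ethylamino)pyridin-4-yl group and meta to a large group, here it stands para to a large group. Going by the values given here, with only one earlier example, which started from a limit, the step from compound 3 to compound 4 is expected to be small, about a 1.4-fold lower number from compound 3 to compound 4 (0.15 log units; within the scatter), resting on compound 2 moving to compound 1 by an at least 1.7-fold lower number from compound 2 to compound 1 (0.23 log units; that floor lies within the scatter). Compound 4 is therefore estimated at 14000 nM, between 6000 nM and 30000 nM.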

Compound 4, half-maximal inhibitory concentration: 26800 nM
Estimate against measurement, compound 4: 1.9-fold (0.28 log units) below, within the range that was stated.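

In this assay, the same exchange of methoxy for trifluoromethyl, read here as 4-methoxyphenyl to 4-(trifluoromethyl)phenyl, gave a 1.4-fold higher number from compound 3 to compound 4 (0.14 log units; within the scatter), and this step does not separate compound 4 from compound 3. Set beside the earlier example, at a different place on the shared core, the result reads: the same change on two cores in this assay, an at least 1.7-fold lower number (0.23 log units; that floor lies within the scatter) from compound 2 to compound 1 and a 1.4-fold higher number (0.14 log units; within the scatter) from compound 3 to compound 4; the limit leaves it open whether they differ. This does not show that the change carries from one core to the other, nor that it fails to, and the earlier example offers only a floor and not a size, since its starting point, compound 2, is a limit of the assay, > 30000 nM.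

With one measured step and one bounded step, the compounds shown leave open whether any replacement at this para position would produce a step beyond the scatter in this assay, for instance a nitrile or a carboxylic acid in place of the trifluoromethyl. They also leave open whether the ethylamino group matters to these readings, as a longer chain or a free amine there would test, and whether the same exchange would behave alike on a core that gives a fully measured starting value.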